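From 4-ethylphenyl to 3,5-dimethylphenyl: compound 4

The source may report more compounds than this note shows. Statements on the series, on what has been measured and on what is new or still open speak of the compounds shown alone.

In a functional assay on HUVEC cells (Homo sapiens) for cytotoxicity (a lower number here means that less compound is needed, a higher number that more compound is needed for the effect), compound 3 `CCc1ccc(/C=C/C(O)=C2/C(=O)C(C)=C(OC)C(C)(C)C2=O)cc1` stands at "not determined" (no result reported), so the step to compound 4 `COC1=C(C)C(=O)/C(=C(O)/C=C/c2cc(C)cc(C)c2)C(=O)C1(C)C` has no starting number. Compound 4 carries 3,5-dimethylphenyl in place of 4-ethylphenyl on a double-bonded chain carbon bound to a double-bonded chain carbon.

The nearest evidence comes from two other compounds on the shared core. In this assay compound 1 `COC1=C(C)C(=O)/C(=C(O)/C=C/c2cccc(OC)c2)C(=O)C1(C)C` gives 1.6 ug/mL, and compound 2 `COC1=C(C)C(=O)/C(=C(O)/C=C/c2ccccc2OC)C(=O)C1(C)C` gives 1.7 ug/mL. Within the data shown here, the only measured step, 2-methoxyphenyl in place of 3-methoxyphenyl, is a 1.1-fold higher number from compound 1 to compound 2 (0.03 log units; within the scatter), and it lies within the scatter. It bears on the present change only indirectly, since neither compound carries the groups exchanged here. With no measured value for compound 3, no direction can be assigned to the step from it. Compound 4 is therefore expected to sit level with compound 1 and compound 2 in this assay, with no difference beyond the scatter, though the range is kept wide. For compound 4 a value near 1.6 ug/mL is expected, with an estimated range from 0.7 ug/mL to 3.6 ug/mL.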

Compound 4, concentration for half-maximal effect: 2.5 ug/mL
For compound 4 the middle estimate is 1.6-fold (0.19 log units) below the measured one; the measured number falls inside the stated range.
By their numbers in this assay, from the lowest: compounds 1, 2 and 4 (each within the scatter of the next).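

In this assay, 3,5-dimethylphenyl in place of the methoxyphenyl groups on a double-bonded chain carbon bound to a double-bonded chain carbon gives a 1.5-fold higher number from compound 2 to compound 4 (0.17 log units; within the scatter) and a 1.6-fold higher number from compound 1 to compound 4 (0.19 log units; within the scatter) on the shared core. Compound 4 therefore reads level with compound 1 and compound 2 although it carries no methoxy group, which the earlier pair, both methoxyphenyl compounds, could not show. The step from compound 3 cannot be read, and nothing measured here accounts for the level readings.

Still open, from the compounds shown here alone, is whether a phenyl ring carrying an amine or a carboxylic acid at this place would stay level with compound 1, compound 2 and compound 4. Equally open, going by these compounds, is whether a longer chain between the ring and the shared core would do so.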